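Chain extension by one carbon in the diketoamide series

A few compounds are considered here, and "the series" means these few. Any claim that something is new, unique, unknown or untested is made for them only; others in the source may bear on it.

Among the measured compounds shown here, compound 2 `CCCCCCCCCCCCCC(=O)CC(=O)Nc1c(C(C)C)cccc1C(C)C` gives the lowest of the two numbers so far in a functional assay on microsomes from intestine for inhibition of acyl-CoA:cholesterol acyltransferase (Oryctolagus cuniculus) (on this read-out higher numbers stand for weaker inhibition and lower numbers for stronger inhibition), with 6 nM; compound 1 `CC(C)c1cccc(C(C)C)c1NC(=O)CC(=O)CCCCCCCCCCOC1CCCCO1` is nearest, at 57 nM. Compound 3 `CCCCCCCCCCCCCCC(=O)CC(=O)Nc1c(C(C)C)cccc1C(C)C` differs from compound 2 by methyl in place of hydrogen on a saturated chain carbon, ten or more bonds along the chain from a carbonyl carbon. For the measured compounds named here, the only step at hand, a 9.5-fold lower number from compound 1 to compound 2 (0.98 log units; beyond the scatter), concerns the same place on the chain but a larger exchange, so it bears only loosely on the present one. For compound 3 the expected step in this assay is a 1.2-fold lower number from compound 2 to compound 3 (0.08 log units; within the scatter), not beyond the scatter. Compound 3 is therefore estimated at 5 nM, with a range from 2 nM to 15 nM.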

Compound 3, half-maximal inhibitory concentration: 24 nM
Beside the measured number, compound 3's estimate is 4.8-fold (0.68 log units) below it; the measured number lies above the stated range.
By their numbers in this assay, from the lowest: compound 2; then compound 3; then compound 1.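

In this assay, one added carbon at this place on the chain is not silent: the change of methyl in place of hydrogen gives a 4.0-fold higher number from compound 2 to compound 3 (0.60 log units; beyond the scatter), so the position responds even to a single carbon. Butyl in place of (oxan-2-yl)oxy still gives a 2.4-fold lower number from compound 1 to compound 3 (0.38 log units; beyond the scatter). Nothing at hand accounts for the rise.

From the compounds shown here alone, whether a longer chain raises the number further, or a shorter chain lowers it below that of compound 2, remains open. So does the effect of a hydroxyl or carboxylic acid at this place.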